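This account rests on a few compounds, and the source may have more. Where it says the series, first, only, none or still open, it means among the compounds named here.

Measured so far:
compound 1, `CC(C)(C)c1ccc(Nc2nc3nonc3nc2O)cc1`: in an assay on mitochondria from L6 cells (Rattus norvegicus) for activation, with a stated time of 90 min (a lower number here means that less compound is needed, a higher number that more compound is needed for the effect), compound 1 gives 3900 nM
compound 2, `CCc1ccc(Nc2nc3nonc3nc2O)c(F)c1`: in this assay compound 2 gives 6700 nM

Compound 1 has the lowest of the two numbers in this assay; the nearest is compound 2, and the gap between the two values lies within the usual scatter, so no order between the two is claimed. Going by the values given here, no step between measured compounds that differ in one place is available, so nothing in the measured pair says how a single change on the shared core moves the read-out.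

Compound 3, `Oc1nc2nonc2nc1Nc1ccc(OC(F)(F)Cl)cc1`, remains to be measured in this assay. Relative to compound 1 the change is chloro(difluoro)methoxy in place of tert-butyl on an aromatic carbon. The shared core is kept; only the group on the aromatic carbon is exchanged. Neither compound 1 nor compound 2 carries chloro(difluoro)methoxy, so the measured numbers give no direct guide to this change. Among the compounds with values here, with no such step in hand, the expected step of a 1.1-fold lower number from compound 1 to compound 3 (0.05 log units; within the scatter) is no larger than the scatter, in no preferred direction. The estimate for compound 3 in this assay is therefore 3500 nM, with a range from 1200 nM to 10000 nM.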

Compound 3, half-maximal effective concentration: 1900 nM
The estimate for compound 3 lay 1.8-fold (0.27 log units) above the measured number; the range from low to high includes it.
By their numbers in this assay, from the lowest: compound 3; then compounds 1 and 2 (each within the scatter of the next).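

In this assay, going by these compounds alone, the exchange of tert-butyl for chloro(difluoro)methoxy on an aromatic carbon gives the first reading of a single change, a 2.1-fold lower number from compound 1 to compound 3 (0.31 log units; beyond the scatter), a modest step but one beyond the scatter. The earlier pair offered no such reading; this step shows that the read-out at this position, para to a large group, responds to the group it carries, and that here the exchange goes with less compound being needed for the effect. The entering group differs from tert-butyl in several counted ways at once, with 5 heavy atoms in place of 4, one hydrogen-bond acceptor in place of none, and oxygen, fluorine and chlorine in the group, and no accompanying measurement links the step to any one of these.

Still open, going by these compounds, is which part of the entering group goes with the step; methoxy and trifluoromethoxy on the same aromatic carbon would separate the oxygen link from the halogens, while an amine or a carboxylic acid there would test a much different kind of group. Also open, on these data alone, is whether the step carries over to a ring that also bears fluorine, as in compound 2.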